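A Further Hydroxy on a Core Already at the Limit

The compounds below may be only part of what the source reports. "The series", "measured", "known", "first", "only" and "open" are said of these compounds alone.

Compound 3 `COc1cc2c(cc1O)O[C@H](c1ccccc1)[C@@H](O)C2=O` stands at the edge of what a functional assay on HeLa cells (Homo sapiens) for cytotoxicity, read by MTT assay, with a stated time of 72 h (on this read-out higher numbers stand for weaker inhibition and lower numbers for stronger inhibition), can resolve. In this assay compound 3 gives > 100000 nM, which is a limit of the assay and not a number. Compound 2 `O=C1c2ccc(O)cc2O[C@H](c2ccccc2)[C@H]1O` likewise gives a limit in this assay, > 100000 nM. For the measured compounds named here, compound 1 `COc1cc2c(cc1O)O[C@H](c1ccccc1)CC2=O`, the only member with a measured number, gives 5600 nM in this assay. Adding hydroxy in place of hydrogen on a saturated ring carbon produced an at least 17-fold higher number from compound 1 to compound 3 (1.25 log units; beyond the scatter), whereas the methoxy in place of hydrogen on an aromatic carbon gives a step that the two limits leave unreadable from compound 2 to compound 3 because the limit of > 100000 nM in this assay, at which 2 of the 3 values shown sit, holds both ends of that step.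

Compound 4 `COc1c(O)cc2c(c1O)C(=O)[C@H](O)[C@@H](c1ccccc1)O2` differs from compound 3 by hydroxy in place of hydrogen on an aromatic carbon. Going by the values given here, no measured step tracks this particular change directly; the one aromatic substitution recorded, from compound 2 to compound 3, is unreadable, and the only readable step, from compound 1 to compound 3, moved the number upward to the limit. With compound 3 already at the limit, the expected step of a number no higher from compound 3 to compound 4 (the limit leaves the size open) is none beyond the scatter, with compound 4 most likely returning another limit. Compound 4 is therefore estimated at 100000 nM in this assay, within a range of 30000 nM to 300000 nM.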

Compound 4, half-maximal inhibitory concentration: > 100000 nM
Compound 4 ended at the assay's limit; the forecaster's own chance of this, stated with the estimate: 70%; the middle value lies on the limit itself.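

Between compound 3 and compound 4 no step can be read in this assay, as both values are limits of the assay and not numbers: the limit of > 100000 nM in this assay, at which 3 of the 4 values shown sit.

The compounds shown leave open what hydroxy or methoxy on the aromatic ring does to the number on a core without the saturated-ring hydroxy, where compound 1 alone gives a measured number.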